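Hydroxyphenyl for Trimethoxyphenyl on the Hydrazone Carbon

A few compounds are considered here, and "the series" means these few. Any claim that something is new, unique, unknown or untested is made for them only; others in the source may bear on it.

Compound 1 `COc1cc(COc2ccc(C(=O)N/N=C/c3ccc(OC)c(OC)c3OC)cc2)cc(OC)c1OC` and compound 2 `COc1cc(/C=N/NC(=O)c2ccc(OCc3cc(OC)c(OC)c(OC)c3)cc2)cc(OC)c1OC` share one core and differ only in the aryl group on the carbon with a double bond to nitrogen. In a physicochemical assay, with a stated time of 30 min (on this read-out higher numbers stand for weaker inhibition and lower numbers for stronger inhibition), compound 1 gives only a limit of the assay, > 100 ug/mL. In this assay compound 2 also gives only a limit, > 100 ug/mL. The step that the two limits leave unreadable from compound 1 to compound 2 therefore cannot be sized, because of the limit of > 100 ug/mL in this assay, at which 2 of the 2 values shown sit. Within the data shown here, compound 2 thus stands at a limit, and the one further value shown is a limit as well.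

Compound 3 `COc1cc(COc2ccc(C(=O)N/N=C/c3ccc(O)cc3)cc2)cc(OC)c1OC` changes compound 2 in one place: 4-hydroxyphenyl in place of 3,4,5-trimethoxyphenyl on a carbon with a double bond to nitrogen. Among the measured compounds shown here, no measured step covers this change; the only step on record, a step that the two limits leave unreadable from compound 1 to compound 2, is unreadable, so neither a direction nor a size beyond the scatter can be drawn from it. The expectation rests only on where compound 2 sits, and a limit is again the most likely outcome. Compound 3 is expected in this assay to give about 100 ug/mL, with a range from 30 ug/mL to 300 ug/mL. The expected step is a number no higher from compound 2 to compound 3 (the limit leaves the size open), an estimate and no measurement.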

Compound 3, half-maximal inhibitory concentration: > 100 ug/mL
Compound 3: a limit, no number (the forecaster's own chance of this, stated with the estimate: 60%); the middle value sits exactly at the limit.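

Compound 3, like compound 1 and compound 2, gives only a limit in this assay, so none of the steps among these three compounds can be read, because no measured number stands on either side of them: the limit of > 100 ug/mL in this assay, at which 3 of the 3 values shown sit.

The compounds shown leave open how strongly each one inhibits and whether the aryl group on the hydrazone carbon affects this read-out at all.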